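This account rests on a few compounds, and the source may have more. Where it says the series, first, only, none or still open, it means among the compounds named here.

In a functional assay on PC-3 cells (Homo sapiens) for antiproliferative activity, read by sulforhodamine B assay, with a stated time of 48 h (a lower number here means a stronger inhibitor of growth, a higher number a weaker inhibitor of growth), compound 2 `CC(C)CCc1c(OCCCCCCCC(=O)NO)ccc2ccc(=O)oc12` gives 1730 nM. Compound 3 `CC(C)CCc1c(OCCCCCCCC(=O)NO)ccc(CCC(=O)NO)c1O` gives 1730 nM, level with compound 2 within the scatter. Compound 1 `CC(C)CCc1c(OCCCCCCC(=O)NO)ccc2c1OC(=O)CC2` reaches only a limit of the assay, > 30000 nM.

Compound 4 `CC(C)CCc1c(OCCCCCCC(=O)NO)ccc2ccc(=O)oc12` is the next point: hydroxycarbamoyl in place of (hydroxycarbamoyl)methyl on a saturated chain carbon, six bonds along the chain from an oxygen on an aromatic ring. The change puts hydroxycarbamoyl in place of (hydroxycarbamoyl)methyl on a saturated chain carbon, six bonds along the chain from an oxygen on an aromatic ring, so 4-(hydroxycarbamoyl)butyl becomes 3-(hydroxycarbamoyl)propyl.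

Among the measured compounds shown here, no measured pair shows this change directly. A small expected move toward weaker growth inhibition in this assay, about the size of the scatter, is the working assumption, with an estimated 1.4-fold higher number from compound 2 to compound 4 (0.16 log units; within the scatter). For compound 4 the expected value is 2500 nM, with an estimated range of 800 nM to 9000 nM.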

Compound 4, concentration for 50% growth inhibition: 520 nM
Estimate against measurement, compound 4: 4.8-fold (0.68 log units) above, and the stated range ends above it.
By their numbers in this assay, from the lowest: compound 4; then compounds 2 and 3 (each within the scatter of the next). At a limit, above all of these: compound 1.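

In this assay, going from 4-(hydroxycarbamoyl)butyl to 3-(hydroxycarbamoyl)propyl gives a 3.3-fold lower number from compound 2 to compound 4 (0.52 log units; beyond the scatter), so chain length at this position counts on this core. This single step gives direction only between these two lengths. The same chain does not suffice on every core, as compound 1 carries it and still stands at a limit of the assay: the limit of > 30000 nM in this assay, at which 1 of the 4 values shown sits.

On these data alone, whether a shorter 2-(hydroxycarbamoyl)ethyl chain continues the gain or reverses it stays open. So does whether a carboxylic acid in place of the hydroxycarbamoyl end keeps any of the growth inhibition.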